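The source may hold more compounds than are shown below. What is called first, only, known or untested is meant among the compounds shown, and "the series" means these compounds.

Compound 1 `Cc1cc2nc(-c3ccco3)n(-c3ccc4c(N)nc(N)nc4c3)c2cc1C` gives 943 nM in an assay on isolated protein for inhibition of Dihydrofolate reductase (Homo sapiens), read by spectrophotometry, using NADPH, with a stated time of 10 min; a higher number here means a weaker inhibitor, a lower number a stronger inhibitor. Compound 2 `Cc1cc2nc(-c3cccs3)n(-c3ccc4c(N)nc(N)nc4c3)c2cc1C` gives 1030 nM in the same assay.

Compound 1 holds the lower of these two numbers, with compound 2 nearest; the step of a 1.1-fold higher number from compound 1 to compound 2 (0.04 log units; within the scatter) lies within the scatter. Compound 3 `Cc1cc2nc(-c3cncn3C)n(-c3ccc4c(N)nc(N)nc4c3)c2cc1C` differs from compound 1 by 1-methyl-1H-imidazol-5-yl in place of furan-2-yl on an aromatic carbon. Among the compounds with values here, the only measured step that bears on this change is the swap from compound 1 to compound 2, which barely moved this assay. Compound 3 is therefore expected to stay close to compound 1, with the step of a 1.1-fold higher number from compound 1 to compound 3 (0.03 log units; within the scatter) estimated to fall within the scatter. The estimate for compound 3 is 1000 nM, in the range 350 nM to 3000 nM.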

Compound 3, inhibition constant: 2920 nM
The estimate for compound 3 lay 2.9-fold (0.47 log units) below the measured number; the range from low to high includes it.
By their numbers in this assay, from the lowest: compounds 1 and 2 (each within the scatter of the next); then compound 3.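

Replacing the ring with 1-methyl-1H-imidazol-5-yl shows that this position is not indifferent to the five-membered aromatic ring it carries. this assay gives a 3.1-fold higher number from compound 1 to compound 3 (0.49 log units; beyond the scatter) and a 2.8-fold higher number from compound 2 to compound 3 (0.45 log units; beyond the scatter), whereas furan-2-yl and thiophen-2-yl could not be told apart. No measurement at hand accounts for this rise.

On these data alone, whether the second ring nitrogen or the methyl group carries the step stays open, since the change alters both at once. Also open, as far as these compounds go, is how a phenyl ring or an aliphatic amine would fare at this position.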